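This account rests on a few compounds, and the source may have more. Where it says the series, first, only, none or still open, it means among the compounds named here.

Working notes on the series. All compounds share one core, varied at a single aromatic carbon. Compound 1 `Cc1cc(-c2c(C)nn(C)c2C)ccc1-c1nnc(N(C)Cc2ccc3nccn3c2)o1` carries the dimethylated pyrazole; in an assay on isolated protein for inhibition of tyrosine-protein kinase Mer (Homo sapiens), read by LC-MS (a higher number here means a weaker inhibitor, a lower number a stronger inhibitor), compound 1 gives 3.16 nM. Compound 2 `Cc1cc(-c2c(C#N)nn(C)c2C)ccc1-c1nnc(N(C)Cc2ccc3nccn3c2)o1` puts cyano in place of methyl on an aromatic carbon, and compound 2 gives 31.6 nM, a step of a 10-fold higher number from compound 1 to compound 2 (1.00 log units; beyond the scatter). Compound 3 `Cc1cc(-c2c(C)nn(C(F)F)c2C)ccc1-c1nnc(N(C)Cc2ccc3nccn3c2)o1` instead carries difluoromethyl on an aromatic nitrogen; compound 3 gives 501 nM. This is the highest of the three numbers, with a 160-fold higher number from compound 1 to compound 3 (2.20 log units; beyond the scatter) and a 16-fold higher number from compound 2 to compound 3 (1.20 log units; beyond the scatter), so compound 3 is the weakest inhibitor of the measured set.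

Compound 4 `Cc1cc(-c2c(C)nc(C)n2C)ccc1-c1nnc(N(C)Cc2ccc3nccn3c2)o1` is not yet measured. It differs from compound 3 by 1,2,4-trimethyl-1H-imidazol-5-yl in place of 1-(difluoromethyl)-3,5-dimethyl-1H-pyrazol-4-yl on an aromatic carbon. Within the data shown here, no measured step exchanges the ring itself, so that part of the change is uncharted. What does bear on it is the substituent on the ring nitrogen: the entry of difluoromethyl there costs a 160-fold higher number from compound 1 to compound 3 (2.20 log units; beyond the scatter), and compound 4 returns to a methyl on that nitrogen, as compound 1 has. A large step downward in this assay is therefore expected, though short of full recovery given the untested ring exchange. Compound 4 is estimated at 10 nM, within 2 nM to 60 nM, which would be an expected step of a 50-fold lower number from compound 3 to compound 4 (1.70 log units; beyond the scatter).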

Compound 4, half-maximal inhibitory concentration in the tyrosine-protein kinase Mer assay: 39.8 nM
For compound 4 the middle estimate is 4.0-fold (0.60 log units) below the measured one, and the stated range covers the measured number.
By their numbers in the tyrosine-protein kinase Mer assay, from the lowest: compound 1; then compounds 2 and 4 (each within the scatter of the next); then compound 3.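

In the tyrosine-protein kinase Mer assay, exchanging the ring itself at this aromatic carbon has a real effect, even with methyl groups alone on both rings: a 13-fold higher number from compound 1 to compound 4 (1.10 log units; beyond the scatter). In the tyrosine-protein kinase Mer assay, 1,2,4-trimethyl-1H-imidazol-5-yl recovers only part of what is lost with 1-(difluoromethyl)-3,5-dimethyl-1H-pyrazol-4-yl, at a 13-fold lower number from compound 3 to compound 4 (1.10 log units; beyond the scatter), and it cannot be told apart from 3-cyano-1,5-dimethyl-1H-pyrazol-4-yl, at a 1.3-fold higher number from compound 2 to compound 4 (0.10 log units; within the scatter). In a physicochemical assay for lipophilicity, at pH 7.4 (a higher number here means a more lipophilic compound, a lower number a more polar compound), compound 3 gives 4.1 and compound 4 gives 2.6. The recovery from compound 3 to compound 4 also comes with a less lipophilic compound: the measured distribution coefficient of compound 3, 4.1, and of compound 4, 2.6, a number 1.50 log units lower (beyond the scatter).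

The compounds shown leave open whether the loss on moving from 1,3,5-trimethyl-1H-pyrazol-4-yl to 1,2,4-trimethyl-1H-imidazol-5-yl follows from the ring atoms or from where the methyl groups sit, and whether the inhibition and lipophilicity changes from compound 3 to compound 4 are linked at all. An ethyl or cyclopropyl group on the ring nitrogen, or a hydroxymethyl group in place of a ring methyl, would show how far the substituents on either ring can be varied at this position.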